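The source may report more compounds than this note shows. Statements on the series, on what has been measured and on what is new or still open speak of the compounds shown alone.

Measured compounds in this series:

compound 1 `Cc1ccc(/C=N/NC(=O)CSc2nnnn2C)cc1` — 3160000 nM
compound 2 `Cn1nnnc1SCC(=O)N/N=C/c1cccc([N+](=O)[O-])c1` — 2000000 nM

Both numbers come from an ADME assay on NIH3T3 cells (Mus musculus) for cytotoxicity, read by XTT assay, with a stated time of 24 h; a higher number here means a weaker inhibitor, a lower number a stronger inhibitor. Compound 1 gives 3160000 nM and compound 2 gives 2000000 nM; the gap between them lies within the usual scatter, so no separation between the two is established and compound 2 cannot be set apart from compound 1 on these figures. Both stand in the weakly cytotoxic region of this assay.

Compound 3 `Cn1nnnc1SCC(=O)N/N=C/c1cccc(Br)c1` has not been measured. It differs from compound 2 in one place: bromo in place of nitro on an aromatic carbon. Among the measured compounds shown here, no step between measured compounds covers a change of this kind, so nothing shows what a bromo in place of a nitro does here. With compound 2 giving 2000000 nM and compound 1, a differently substituted analogue, giving a figure within the scatter of it, the expectation for compound 3 is no step beyond the scatter, a 1.3-fold higher number from compound 2 to compound 3 (0.10 log units; within the scatter). Compound 3 is therefore estimated at 2500000 nM, in the range 1000000 nM to 6000000 nM.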

Compound 3, half-maximal inhibitory concentration: 316000 nM
The estimate for compound 3 lay 7.9-fold (0.90 log units) above the measured number; the measured number lies below the stated range.
By their numbers in this assay, from the lowest: compound 3; then compounds 2 and 1 (each within the scatter of the next).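

In this assay, the group on this aromatic carbon, meta to a large group, proves able to move the number: bromo in place of nitro gives a step beyond the scatter (a 6.3-fold lower number from compound 2 to compound 3 (0.80 log units; beyond the scatter)). Compounds 1 and 2 had shown no separation, and their figures could have suggested a series insensitive to its aromatic substituent, but the pair of compound 2 and compound 3 rules that reading out for this change. Nothing available accounts for the size or direction of the step.

On these data alone, whether the lower number comes from the arrival of bromo or the departure of nitro remains open, since this single pair cannot separate the two. A chloro group, a methoxy group or an amine at the same place would help to separate them.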